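The source may report more compounds than this note shows. Statements on the series, on what has been measured and on what is new or still open speak of the compounds shown alone.

Measured so far:
Compound 1 `Fc1ccc2nc(-c3ccccc3)nc(Nc3ccccc3)c2c1` — in a functional assay on MDA-MB-231 cells (Homo sapiens) for cytotoxicity, read by MTT assay, with a stated time of 48 h (a higher number here means a weaker inhibitor, a lower number a stronger inhibitor), compound 1 reports only a limit, > 50000 nM.
Compound 2 `Fc1cccc(-c2nc(Nc3cccc(Cl)c3)c3cc(F)ccc3n2)c1` — in this assay compound 2 likewise reports only a limit, > 50000 nM.

Compound 2 therefore stands not at a number but at the edge of what this assay can see, and so does compound 1: both values sit at the limit of > 50000 nM in this assay, at which 2 of the 2 values shown sit. Going by the values given here, with two limits and no measured number, no step between them can be sized, and nothing yet shows what any change to the shared core does to cytotoxicity.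

Compound 3 `Nc1cccc(Nc2nc(-c3cccc(F)c3)nc3ccc(F)cc23)c1` differs from compound 2 by amino in place of chloro on an aromatic carbon. Among the compounds with values here, no measured pair involves this change, so its effect is unknown; the one thing known is that both measured compounds sit at the limit. The step of an at least 1.2-fold lower number from compound 2 to compound 3 (0.09 log units; that floor lies within the scatter) is therefore expected to be small, with a real chance that only a limit is reported again. Compound 3 is estimated at 40000 nM, expected to lie between 5000 nM and 100000 nM.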

Compound 3, half-maximal inhibitory concentration: > 50000 nM
Compound 3 ended at the assay's limit; the forecaster's own chance of this, stated with the estimate: 60%; middle value at least 1.2-fold (0.09 log units) away from the limit.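

Going by these compounds alone, compound 2 and compound 3 both report only a limit in this assay, so no step between them can be read. All the compounds shown stand at the same edge: the limit of > 50000 nM in this assay, at which 3 of the 3 values shown sit. The compounds shown leave open whether amino in place of chloro, or any other change to the shared core, alters cytotoxicity at all.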